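Removing Two Fluorines: An Expected Loss in Cytotoxicity

A few compounds are considered here, and "the series" means these few. Any claim that something is new, unique, unknown or untested is made for them only; others in the source may bear on it.

Compound 1 `COc1ccc(/C=C/c2cc(OC)c(OC)c(OC)c2-c2ccc(F)c(F)c2)cc1` gives 7500 nM in a functional assay on DU-145 cells (Homo sapiens) for cytotoxicity, read by MTT assay, with a stated time of 48 h; on this read-out lower numbers stand for stronger inhibition and higher numbers for weaker inhibition. Compound 2 `COc1ccc(/C=C/c2cc(OC)c(OC)c(OC)c2-c2ccccc2)cc1` differs from it by phenyl in place of 3,4-difluorophenyl on an aromatic carbon, and in this assay compound 2 gives 51000 nM, a 6.8-fold higher number from compound 1 to compound 2 (0.83 log units; beyond the scatter). Compound 3 `C=C(c1ccc(OC)cc1)c1cc(OC)c(OC)c(OC)c1-c1ccc(F)c(F)c1` has the same atoms as compound 1, joined differently, through (1-(4-methoxyphenyl)ethenyl in place of 2-(4-methoxyphenyl)ethenyl on an aromatic carbon); in this assay compound 3 gives 6800 nM, which is a 1.1-fold lower number from compound 1 to compound 3 (0.04 log units; within the scatter). Compound 4 `C=C(c1ccc(OC)cc1)c1cc(OC)c(OC)c(OC)c1-c1ccccc1` is not yet measured; it differs from compound 3 by phenyl in place of 3,4-difluorophenyl on an aromatic carbon. This is the same kind of change as that made from compound 1 to compound 2, though here the place is ortho to a 1-(4-methoxyphenyl)ethenyl group rather than ortho to a 2-(4-methoxyphenyl)ethenyl group. The step is expected to be about a 6.8-fold higher number from compound 3 to compound 4 (0.83 log units; beyond the scatter), matching the earlier one, because a 6.8-fold higher number from compound 1 to compound 2 (0.83 log units; beyond the scatter) was seen for the same kind of change. Compound 4 is therefore expected to give roughly 46000 nM in this assay, with a plausible range from 20000 nM to 110000 nM.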

Compound 4, half-maximal inhibitory concentration: 8000 nM
For compound 4 the middle estimate is 5.8-fold (0.76 log units) above the measured one; the measured number lies below the stated range.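

In this assay, phenyl in place of 3,4-difluorophenyl gives a 1.2-fold higher number from compound 3 to compound 4 (0.07 log units; within the scatter), so on this core the two groups cannot be told apart. These two pairs show that the change does not carry over as one fixed step, but they do not show what in the two cores sets the steps apart, and they give no rule for any further core. The size of the step depended on the core that bore it: the same change on two cores in this assay, a 6.8-fold higher number (0.83 log units; beyond the scatter) from compound 1 to compound 2 and a 1.2-fold higher number (0.07 log units; within the scatter) from compound 3 to compound 4, 5.8-fold (0.76 log units) apart, beyond the scatter of two such steps

Going by these compounds, it remains open how a chlorine, a methyl group or an amine on the phenyl would read on either core. On these data alone, whether a carboxylic acid there would give the same result on both cores also remains open.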